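Trading the acid chain for a methoxy group

The compounds below may be only part of what the source reports. "The series", "measured", "known", "first", "only" and "open" are said of these compounds alone.

Compound 1 `O=C(Nc1ccc2nc(NC(=O)C3CCCCC3)sc2c1)c1c(Cl)cccc1Cl` gives 0.015 ug/mL in a functional assay on WI-38 VA13 cells (Homo sapiens) for cytotoxicity; a higher number here means that more compound is needed for the effect, a lower number that less compound is needed. Compound 2 `CC(=O)Nc1nc2ccc(NC(=O)c3c(Cl)cccc3Cl)cc2s1`, which carries methyl in place of cyclohexyl on a carbonyl carbon, gives 0.6 ug/mL in this assay, a change of a 40-fold higher number from compound 1 to compound 2 (1.60 log units; beyond the scatter). Compound 3 `O=C(O)CCC(=O)Nc1nc2ccc(NC(=O)c3c(Cl)cccc3Cl)cc2s1` reaches only a bound of this assay, reported as > 6.6 ug/mL, which is a limit and not a number (the limit of > 6.6 ug/mL in this assay, at which 1 of the 3 values shown sits). The step of an at least 440-fold higher number from compound 1 to compound 3 (2.64 log units; beyond the scatter) and the step of an at least 11-fold higher number from compound 2 to compound 3 (1.04 log units; beyond the scatter) are both large, and both bring the 2-carboxyethyl group in, so compound 3 stands weakest of the three on the numbers shown.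

Compound 4 `COC(=O)Nc1nc2ccc(NC(=O)c3c(Cl)cccc3Cl)cc2s1` has not yet been tested. The change from compound 3 is methoxy in place of 2-carboxyethyl on a carbonyl carbon. The 2-carboxyethyl group leaves and a small neutral group takes its place, so the situation resembles compound 2 with its small methyl and its 0.6 ug/mL. The two steps into compound 3 were large, and the step out of it is expected to run the other way, though the size cannot be pinned down from a limit. Compound 4 is therefore expected to give about 0.8 ug/mL, between 0.15 ug/mL and 5 ug/mL, in this assay. This estimate means an at least 8.2-fold lower number from compound 3 to compound 4 (0.91 log units; beyond the scatter).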

Compound 4, half-maximal effective concentration: 0.0095 ug/mL
For compound 4 the middle estimate is 84-fold (1.93 log units) above the measured one; measured number outside the range, below it.
By their numbers in this assay, from the lowest: compounds 4 and 1 (each within the scatter of the next); then compound 2. At a limit, above all of these: compound 3.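

A short group at this place, on a carbonyl carbon whose other neighbour is an amide-type nitrogen, does not by itself give a weak number: swapping methyl for methoxy, a change of very few atoms, gives a 63-fold lower number from compound 2 to compound 4 (1.80 log units; beyond the scatter) in this assay. Among these compounds, this goes against the impression left by the earlier compounds, where shortening the group from cyclohexyl to methyl raised the number, and it shows that the cyclohexyl ring is not needed for a low value, since a 1.6-fold lower number from compound 1 to compound 4 (0.20 log units; within the scatter) leaves these two compounds indistinguishable in this measurement. The step away from the 2-carboxyethyl group, an at least 690-fold lower number from compound 3 to compound 4 (2.84 log units; beyond the scatter), starts from a limit and not from a number: the limit of > 6.6 ug/mL in this assay, at which 1 of the 4 values shown sits.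

The compounds shown leave open whether an ethoxy group, a longer chain on the same oxygen or an amine in place of the methoxy would keep the number this low. Nothing here explains the gap between methyl and methoxy, and that contrast rests on a single pair of compounds.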